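A few compounds are considered here, and "the series" means these few. Any claim that something is new, unique, unknown or untested is made for them only; others in the source may bear on it.

In a functional assay on CCRF-CEM cells (Homo sapiens), read by MTT assay, with a stated time of 72 h (on this read-out lower numbers stand for stronger inhibition and higher numbers for weaker inhibition), compound 2 `CN(C)c1ncnc2c1c(-c1ccoc1)cn2[C@@H]1O[C@H](CO)[C@@H](O)[C@H]1O` gives 13300 nM and compound 3 `CN(C)c1ncnc2c1c(-c1ccsc1)cn2[C@@H]1O[C@H](CO)[C@@H](O)[C@H]1O` gives 3480 nM, the lower of these two numbers. Compound 4 `CN(C)c1ncnc2c1c(-c1cc3ccccc3o1)cn2[C@@H]1O[C@H](CO)[C@@H](O)[C@H]1O` puts 1-benzofuran-2-yl in place of thiophen-3-yl on an aromatic carbon. Compound 1 `CNc1ncnc2c1c(-c1cc3ccccc3o1)cn2[C@@H]1O[C@H](CO)[C@@H](O)[C@H]1O`, which also carries 1-benzofuran-2-yl, gives > 20000 nM, a limit of the assay and not a number, and this points towards a higher number for that group. Among the measured compounds shown here, the only measured swap at this carbon, thiophen-3-yl in place of furan-3-yl, gave a 3.8-fold lower number from compound 2 to compound 3 (0.58 log units; beyond the scatter), so a step of similar size towards a higher number is expected, a 3.4-fold higher number from compound 3 to compound 4 (0.54 log units; beyond the scatter). Compound 4 is estimated at 12000 nM, with an expected range of 4000 nM to 30000 nM.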

Compound 4, half-maximal inhibitory concentration: > 20000 nM
Compound 4: a limit, no number; the forecaster's own chance of this, stated with the estimate: 45%; middle value at least 1.6-fold (0.22 log units) from the limit.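

At this carbon, 1-benzofuran-2-yl gives an at least 5.7-fold higher number from compound 3 to compound 4 (0.75 log units; beyond the scatter), so the lower number of compound 3 does not carry over to this two-ring group. Against furan-3-yl the change is an at least 1.5-fold higher number from compound 2 to compound 4 (0.17 log units; that floor lies within the scatter), so compound 4 cannot be ranked against compound 2. Compound 4 gives a limit and not a number, as does compound 1, so the step between those two cannot be read: the limit of > 20000 nM in this assay, at which 2 of the 4 values shown sit.

From the compounds shown here alone, how far beyond that limit compound 4 lies stays open. Also open, going by these compounds, is how a plain phenyl ring or a thiophen-2-yl group would behave on this carbon.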